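The source may report more compounds than this note shows. Statements on the series, on what has been measured and on what is new or still open speak of the compounds shown alone.

In a functional assay on RAW264.7 cells (Mus musculus) for inhibition, read by microscopy, with a stated time of 4 days, in the presence of a further agent that is not named here (on this read-out higher numbers stand for weaker inhibition and lower numbers for stronger inhibition), compound 1 `O=C(Nc1ccc(Cl)cc1F)c1cc(Cl)ccc1O` gives 2120 nM.
In this assay compound 2 `O=C(Nc1ccc(Cl)cc1F)c1ccccc1O` gives 10000 nM.
In this assay compound 3 `O=c1oc2ccc(Cl)cc2c(=O)n1-c1ccc(I)cc1F` gives 2050 nM.

Compound 1 and compound 2 differ in one place: hydrogen in place of chloro on an aromatic carbon. That change gave a 4.7-fold higher number from compound 1 to compound 2 (0.67 log units; beyond the scatter). Compound 3 is built on another core; how its core differs from that of compound 1 is not broken down here. The values of compound 3 and compound 1 lie within the usual scatter of each other, whereas compound 2 sits beyond the scatter from both.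

Compound 4 `O=c1oc2ccccc2c(=O)n1-c1ccc(I)cc1F` has not yet been measured. It differs from compound 3 by hydrogen in place of chloro on an aromatic carbon. The surroundings are not the same as in the earlier pair: in compound 1 the carbon is meta to a large group and para to a hydroxy group, while in compound 3 it sits on a six-membered aromatic ring of carbon only that is part of a fused or bridged system of two rings, meta to a fused ring and para to a fused ring. It is thus the same kind of change, not the same change.

In this assay, going by the values given here, the step from compound 3 to compound 4 is expected to be roughly the size seen earlier, because a 4.7-fold higher number from compound 1 to compound 2 (0.67 log units; beyond the scatter) is the only guide available. The expected step is a 3.4-fold higher number from compound 3 to compound 4 (0.53 log units; beyond the scatter). For compound 4 the estimate is 7000 nM, expected to fall between 2500 nM and 20000 nM.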

Compound 4, half-maximal inhibitory concentration: 4900 nM
Compound 4: the middle estimate sits 1.4-fold (0.15 log units) above what was measured; the range from low to high includes it.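

Putting hydrogen in place of chloro on the aromatic carbon again raised the number in this assay, giving a 2.4-fold higher number from compound 3 to compound 4 (0.38 log units; beyond the scatter), so the chloro compound is the stronger one in this pair too. Set beside the earlier pair, the change carries over in direction, and the two step sizes cannot be told apart: the same change on two cores in this assay, a 4.7-fold higher number (0.67 log units; beyond the scatter) from compound 1 to compound 2 and a 2.4-fold higher number (0.38 log units; beyond the scatter) from compound 3 to compound 4, 2.0-fold (0.30 log units) apart, within the scatter of two such steps. This shows that on these two cores the chloro group goes with stronger inhibition in this assay, but two pairs are a small sample, and they do not show why the number rises or that the same would hold on a third core.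

From the compounds shown here alone, only chloro and hydrogen appear at this place, so it remains open what a fluoro, methyl or methoxy group would give there. Going by these compounds, it also remains open whether the step would keep its size if an amine stood in place of the iodo group shared by compound 3 and compound 4.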